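Dropping One Methoxy From the Weakest of Three Benzylthiones

A few compounds are considered here, and "the series" means these few. Any claim that something is new, unique, unknown or untested is made for them only; others in the source may bear on it.

Measured compounds:
compound 1 `COc1ccc(Cn2cc[nH]c2=S)cc1OC`: 339000 nM
compound 2 `COc1c(Cl)cc(Cn2cc[nH]c2=S)cc1Cl`: 46800 nM
compound 3 `Oc1ccc(Cn2cc[nH]c2=S)cc1Br`: 12000 nM

In an assay on isolated protein for inhibition of Dopamine beta-hydroxylase (Rattus norvegicus) (a lower number here means a stronger inhibitor, a higher number a weaker inhibitor), compound 1 gives the highest number of the three, so it is the weakest inhibitor here, with compound 2 and compound 3 both giving markedly lower numbers. Compound 4 `COc1ccc(Cn2cc[nH]c2=S)cc1` keeps the shared core of compound 1 and differs from it in one place: hydrogen in place of methoxy on an aromatic carbon. For the measured compounds named here, no measured pair shows what removing a methoxy does on this core, so the direction of the step is uncertain. Compound 4 is expected to stay close to compound 1, with the estimated step of a 1.7-fold lower number from compound 1 to compound 4 (0.23 log units; within the scatter) lying near the scatter. The expected value for compound 4 in this assay is 200000 nM, between 50000 nM and 800000 nM.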

Compound 4, half-maximal inhibitory concentration: 204000 nM
Compound 4: the middle estimate sits 1.0-fold (0.01 log units) below what was measured; measured number inside the range.
By their numbers in this assay, from the lowest: compound 3; then compound 2; then compounds 4 and 1 (each within the scatter of the next).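

For the compounds shown here, replacing this methoxy, which sits ortho to a methoxy group, with hydrogen gives the first direct reading of this position: in this assay, the step is a 1.7-fold lower number from compound 1 to compound 4 (0.22 log units; within the scatter). On this core, then, the second methoxy is not needed to keep the number where it stands, and a single methoxy does as well as two within the scatter. Nothing measured here explains this result.

As far as these compounds go, it remains open whether a different group at this position, such as an amine or a carboxylic acid, would shift the number beyond the scatter. From the compounds shown here alone, the same swap on a ring that also carries other groups also remains untested by these compounds.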